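Benzyl substituent exchange in a bis-trifluoromethyl sulfonamide series

This account rests on a few compounds, and the source may have more. Where it says the series, first, only, none or still open, it means among the compounds named here.

Three measured compounds share one core and differ only in the group on the benzyl ring. Compound 1 `CC(C)(C)c1ccc(CNCCCNS(=O)(=O)c2cc(C(F)(F)F)cc(C(F)(F)F)c2)cc1` carries tert-butyl there, and in a functional assay on HPAC cells (Homo sapiens) for inhibition, read by MTT assay, with a stated time of 72 h (on this read-out higher numbers stand for weaker inhibition of growth and lower numbers for stronger inhibition of growth), compound 1 gives 2300 nM. Compound 2 `O=S(=O)(NCCCNCc1ccccc1)c1cc(C(F)(F)F)cc(C(F)(F)F)c1` carries hydrogen at that carbon; in this assay compound 2 gives 3200 nM. Compound 3 `COc1ccc(CNCCCNS(=O)(=O)c2cc(C(F)(F)F)cc(C(F)(F)F)c2)cc1` carries methoxy; in this assay compound 3 gives 3000 nM, the second highest of the three numbers, with compound 2 nearest and compound 1 furthest, both inside the scatter. Among the compounds with values here, the step of a 1.4-fold higher number from compound 1 to compound 2 (0.14 log units; within the scatter), the step of a 1.3-fold higher number from compound 1 to compound 3 (0.12 log units; within the scatter) and the step of a 1.1-fold lower number from compound 2 to compound 3 (0.03 log units; within the scatter) all stay within the scatter, so nothing measured so far separates these three groups.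

Compound 4 `O=S(=O)(NCCCNCc1ccc(Cl)cc1)c1cc(C(F)(F)F)cc(C(F)(F)F)c1` is not yet measured. The change from compound 3 is chloro in place of methoxy on an aromatic carbon, on an aromatic carbon of a six-membered aromatic ring of carbon only, para to a large group. Within the data shown here, the steps that bear on it are the exchanges at this same carbon, a 1.3-fold higher number from compound 1 to compound 3 (0.12 log units; within the scatter) and a 1.1-fold lower number from compound 2 to compound 3 (0.03 log units; within the scatter), with a 1.4-fold higher number from compound 1 to compound 2 (0.14 log units; within the scatter) as a third exchange there; none exceeds the scatter. Accordingly no step beyond the scatter is expected in this assay, in either direction. The expected step in this assay is no change at the digits printed from compound 3 to compound 4 (within the scatter). Compound 4 is estimated at 3000 nM in this assay, with a range from 1500 nM to 6000 nM.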

Compound 4, concentration for 50% growth inhibition: 2800 nM
Compound 4: the middle estimate sits 1.1-fold (0.03 log units) above what was measured, within the range that was stated.
By their numbers in this assay, from the lowest: compounds 1, 4, 3 and 2 (each within the scatter of the next).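

Chloro joins tert-butyl, hydrogen and methoxy at this carbon, on an aromatic carbon of a six-membered aromatic ring of carbon only, para to a large group, and in this assay the new exchanges read a 1.1-fold lower number from compound 3 to compound 4 (0.03 log units; within the scatter) and a 1.1-fold lower number from compound 2 to compound 4 (0.06 log units; within the scatter) and also a 1.2-fold higher number from compound 1 to compound 4 (0.09 log units; within the scatter) with all three within the scatter. The series now includes a group with no hydrogen-bond acceptor and a single chlorine atom in place of methoxy, yet across these four compounds no exchange at this carbon separates one group from another, and none of the four goes against that reading. No measurement shown offers any explanation for this flat reading.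

Still open, as far as these compounds go, is whether any other group at this carbon, such as a carboxylic acid or a dimethylamino group, would give a step beyond the scatter in this assay. Also open, from the compounds shown here alone, is whether changes elsewhere on the shared core, such as a longer chain in place of the propyl linker or an amide in place of the sulfonamide, would move the number where exchanges at this carbon do not.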